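Swapping the anilide aryl on a benzyl-bearing core

The source may report more compounds than this note shows. Statements on the series, on what has been measured and on what is new or still open speak of the compounds shown alone.

Compound 1 `COc1ccc(NC(=O)CN2CCN(c3nnc(Cc4ccccc4)c4ccccc34)CC2)cc1OC`: 32200 nM
Compound 2 `O=C(CN1CCN(c2nnc(Cc3ccncc3)c3ccccc23)CC1)Nc1cccc(Br)c1`: 1.7 nM
Compound 3 `O=C(CN1CCN(c2nnc(Cc3ccncc3)c3ccccc23)CC1)Nc1c(F)cccc1F`: 1900 nM

In a functional assay on MDA-MB-231 cells (Homo sapiens) for cytotoxicity, read by MTT assay, with a stated time of 72 h (on this read-out lower numbers stand for stronger inhibition and higher numbers for weaker inhibition), compound 1 stands highest of the three measured compounds, far from compound 2 and well apart from compound 3. Compound 4 `O=C(CN1CCN(c2nnc(Cc3ccccc3)c3ccccc23)CC1)Nc1cc(C(F)(F)F)ccc1Cl` differs from compound 1 at one place: 2-chloro-5-(trifluoromethyl)phenyl in place of 3,4-dimethoxyphenyl on an amide-type nitrogen. Among the compounds with values here, no measured step changes the same pair of groups, and compounds 2 and 3 carry a different core from compound 1, so the only guide is the step of a 1100-fold higher number from compound 2 to compound 3 (3.05 log units; beyond the scatter), which shows that the aryl on the amide-type nitrogen can shift the read-out by a very large amount. Compound 2, with a halogenated phenyl, gives the lowest number, while compound 1, with the dimethoxy-substituted phenyl, gives the highest. On that basis compound 4 is expected to show a markedly lower number than compound 1, with a step of about a 21-fold lower number from compound 1 to compound 4 (1.33 log units; beyond the scatter), though the size is uncertain because the core differs from that of compounds 2 and 3. Compound 4 is therefore estimated at 1500 nM, within a range of 80 nM to 25000 nM.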

Compound 4, half-maximal inhibitory concentration: 19500 nM
Estimate against measurement, compound 4: 13-fold (1.11 log units) below; the range from low to high includes it.
By their numbers in this assay, from the lowest: compound 2; then compound 3; then compounds 4 and 1 (each within the scatter of the next).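

In this assay, placing 2-chloro-5-(trifluoromethyl)phenyl instead of 3,4-dimethoxyphenyl on the amide-type nitrogen gives a 1.7-fold lower number from compound 1 to compound 4 (0.22 log units; within the scatter), so the two aryl groups cannot be told apart on this core. The very large step a 1100-fold higher number from compound 2 to compound 3 (3.05 log units; beyond the scatter) therefore does not carry over to this pair of groups, and a halogen-bearing aryl on the amide-type nitrogen does not by itself give a low number on the core of compound 1. No evidence is available to explain why this exchange leaves the number within the scatter.

The compounds shown leave open whether the 3-bromophenyl of compound 2 would also give a low number on the core of compound 1. On these data alone, it also remains open whether an amine or a carboxylic acid on this aryl would shift the read-out on that core.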